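Adding nonyl to the chain of compound 2

This account rests on a few compounds, and the source may have more. Where it says the series, first, only, none or still open, it means among the compounds named here.

In a functional assay on KB cells (Homo sapiens) for cytotoxicity, read by resazurin assay, with a stated time of 3 days (on this read-out higher numbers stand for weaker inhibition and lower numbers for stronger inhibition), compound 1 `CCCC(C)C(=O)NCC(C)(C)CC1=C(O)C(=O)c2ccccc2C1=O` gives 47100 nM and compound 2 `CCCCCCC(=O)OCC(C)(C)CC1=C(O)C(=O)c2ccccc2C1=O` gives 14400 nM. Among the compounds with values here, compound 2 therefore holds the lower of the two numbers measured so far. Compound 3 `CCCCCCCCCCCCCCCC(=O)OCC(C)(C)CC1=C(O)C(=O)c2ccccc2C1=O` has not yet been measured. It differs from compound 2 by nonyl in place of hydrogen on a saturated chain carbon, six bonds along the chain from a carbonyl carbon, with nonyl in place of hydrogen on a saturated chain carbon, six bonds along the chain from a carbonyl carbon.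

Within the data shown here, only one measured step is available, a 3.3-fold lower number from compound 1 to compound 2 (0.51 log units; beyond the scatter), which was modest. It exchanged ((1-methylbutyl)carbonyl)amino for (hexylcarbonyl)oxy, so it bears on the present change only indirectly. Among the measured compounds shown here, no measured pair shows what lengthening an unbranched chain does in this assay, and the direction remains open. The estimate therefore stays anchored on compound 2 at 14400 nM, with a range wide enough for a modest step either way. The expected change is a 1.4-fold higher number from compound 2 to compound 3 (0.14 log units; within the scatter), which is no clear step beyond the scatter. For compound 3 the estimated value is 20000 nM, with an expected range of 6000 nM to 70000 nM.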

Compound 3, half-maximal inhibitory concentration: 27100 nM
The estimate for compound 3 lay 1.4-fold (0.13 log units) below the measured number; the range from low to high includes it.
By their numbers in this assay, from the lowest: compounds 2, 3 and 1 (each within the scatter of the next, the first and the last beyond it).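

In this assay, nonyl in place of hydrogen on a saturated chain carbon, six bonds along the chain from a carbonyl carbon, gives a 1.9-fold higher number from compound 2 to compound 3 (0.27 log units; within the scatter). Within the data shown here, this is the first pair that differs only in the length of an unbranched chain, and the earlier step, which exchanged ((1-methylbutyl)carbonyl)amino for (hexylcarbonyl)oxy, could not speak to that change. It shows that, at this position, a group as large as nonyl brings no clear step in either direction on this read-out, though a single pair cannot show how the numbers run across other chain lengths. No measured evidence bears on why the two numbers lie so close together.

What the compounds leave open is whether a chain shorter than nonyl, such as propyl, or a longer chain than nonyl would stay within the scatter of compound 2. They also do not show whether an amine or a carboxylic acid in place of nonyl at this carbon would move the number beyond the scatter.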